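Methoxyphenyl Replaces Dichlorophenyl on a Ring Nitrogen

The compounds below may be only part of what the source reports. "The series", "measured", "known", "first", "only" and "open" are said of these compounds alone.

Compound 1 `CCC1(CCCCN2CCN(c3ccc(Cl)c(Cl)c3)CC2)C(=O)Nc2ccccc21` was tested in a functional assay on the whole organism (strain Wistar) with Rattus norvegicus as the target, with a stated time of 5 min; on this read-out higher numbers stand for an effect only at larger amounts of compound and lower numbers for an effect already at smaller amounts. In this assay compound 1 gave only a limit, > 20 mg/kg, so no number is known for it and only an edge of the measurement is. Compound 2 `CCC1(CCCCN2CCN(c3cccc(Cl)c3)CC2)C(=O)Nc2cc(F)ccc21` was run in the same assay. In this assay compound 2 likewise gave only a limit, > 20 mg/kg. For the measured compounds named here, both values shown thus sit at one edge, (the limit of > 20 mg/kg in this assay, at which 2 of the 2 values shown sit), and there is no measured step between any two compounds from which the effect of a change of structure could be read.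

Compound 3 `CCC1(CCCCN2CCN(c3ccccc3OC)CC2)C(=O)Nc2ccccc21` is the compound still to be measured. It differs from compound 1 in one place (2-methoxyphenyl in place of 3,4-dichlorophenyl on an amine nitrogen in a ring). Going by the values given here, since no step has been measured, the data give no hold on the size or direction of this change in this assay, and the step expected here is a number no higher from compound 1 to compound 3 (the limit leaves the size open), which lies within the usual scatter. Compound 3 is therefore estimated at 20 mg/kg, in a range from 5 mg/kg to 80 mg/kg, with a real chance that this assay again reports only a limit.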

Compound 3, minimum effective dose: 10 mg/kg
Compound 3: middle estimate off by 2.0-fold (0.30 log units), on the high side, within the range that was stated.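

For the compounds shown here, with compound 3, this assay gives its first real number here, and with it the first step that can be read at this place on the amine nitrogen in a ring: 2-methoxyphenyl in place of 3,4-dichlorophenyl gives an at least 2.0-fold lower number from compound 1 to compound 3 (0.30 log units; that floor lies within the scatter). The value of compound 1, > 20 mg/kg, is a limit and not a number. The step is therefore only a floor, its true size stays open, and compound 3 is the one compound shown that has left the edge of the measurement: the limit of > 20 mg/kg in this assay, at which 2 of the 3 values shown sit.

This single change removes the two chlorine atoms and brings in a methoxy group, so the compounds shown cannot tell whether the loss of chlorine, the gain of the methoxy group or the place of the new group counts for the result. As far as these compounds go, an unsubstituted phenyl ring, or an ethoxy or hydroxyl group in place of the methoxy group, would pull these parts apart, and how low the number can go with changes on this nitrogen also remains unknown.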